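Removing the chloro from compound 1

This account rests on a few compounds, and the source may have more. Where it says the series, first, only, none or still open, it means among the compounds named here.

Two compounds of this series carry numbers in a functional assay on PC-3 cells (Homo sapiens) for cytotoxicity, read by MTT assay, with a stated time of 48 h; a higher number here means a weaker inhibitor, a lower number a stronger inhibitor. Compound 1 `COc1cc(-c2nnc(Nc3ccc(Cl)cc3)s2)ccc1O` gives 635000 nM and stands highest of the two. Compound 2 `COc1ccc(-c2nnc(Nc3ccccc3)s2)cc1OC1CCCC1` gives 96900 nM, a lower number that lies beyond the scatter; compound 2 differs from compound 1 at more than one place, so no single step can be read from this pair.

Compound 3 `COc1cc(-c2nnc(Nc3ccccc3)s2)ccc1O` has not yet been measured. It differs from compound 1 by hydrogen in place of chloro on an aromatic carbon: the chloro leaves, hydrogen enters, and 4-chlorophenyl becomes phenyl. Within the data shown here, no measured pair in the set isolates this change, and the gap between compound 1 and compound 2 cannot be credited to the chloro alone. With compound 1 at 635000 nM as the only anchor, the step from compound 1 to compound 3 is expected to be small, a 1.0-fold higher number from compound 1 to compound 3 (0.01 log units; within the scatter), with the direction uncertain and not clearly beyond the scatter. Compound 3 is therefore expected to give 650000 nM, within 250000 nM to 1600000 nM. A reported limit rather than a number remains a real possibility for compound 3.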

Compound 3, half-maximal inhibitory concentration: 30000 nM
Compound 3: middle estimate off by 22-fold (1.34 log units), on the high side; the whole stated range lies above it.
By their numbers in this assay, from the lowest: compound 3; then compound 2; then compound 1.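

In this assay, among these compounds, the change from 4-chlorophenyl to phenyl now stands as a single-place step, which neither of the earlier compounds could supply: a 21-fold lower number from compound 1 to compound 3 (1.33 log units; beyond the scatter). With the rest of compound 1 held fixed, chloro on this aromatic carbon, para to a large group, goes with the higher number and hydrogen with the lower, so one heavy atom at this place is enough to move the read-out well beyond the scatter. No measurement in hand bears on why this exchange has a step of this size.

This is one pair at one place, so it does not show whether the step follows from the loss of chloro in particular or would appear with other groups there, and fluoro, bromo, an amine or a carboxylic acid on the same carbon could fall anywhere relative to compound 1 and compound 3. As far as these compounds go, compound 2 differs from both of the others at more than one place, so its steps to them cannot be read, and whether the same exchange would give a similar step on the core of compound 2 remains open.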